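Aryl urea series: dichlorophenyl analogue of compound 3

The source may report more compounds than this note shows. Statements on the series, on what has been measured and on what is new or still open speak of the compounds shown alone.

Measured so far in a functional assay on SK-MEL-5 cells (Homo sapiens) for inhibition, read by sulforhodamine B assay, with a stated time of 48 h, tested at 10 uM; a higher number here means a weaker effect of the compound at the concentration tested, a lower number a stronger effect:
compound 1 `COc1cc2cc(Oc3ccc(NC(=O)Nc4ccccc4)cc3)c(C)nc2cc1OC` gives 60.8%
compound 2 `COc1cc2cc(Oc3ccc(NC(=O)Nc4ccc(C(F)(F)F)cc4)cc3)c(C)nc2cc1OC` gives 47.4%
compound 3 `COc1cc2cc(Oc3ccc(NC(=O)Nc4cccc(C(F)(F)F)c4)cc3)c(C)nc2cc1OC` gives -86.1%

Compound 3 stands lowest of the three, with compound 2 nearest (a number 133.5 percentage points lower from compound 2 to compound 3 (beyond the scatter)) and compound 1 furthest (a number 146.9 percentage points lower from compound 1 to compound 3 (beyond the scatter)). Compound 4 `COc1cc2cc(Oc3ccc(NC(=O)Nc4ccc(Cl)c(Cl)c4)cc3)c(C)nc2cc1OC` differs from compound 3 by 3,4-dichlorophenyl in place of 3-(trifluoromethyl)phenyl on an amide-type nitrogen. Among the measured compounds shown here, no measured step swaps a trifluoromethyl for chlorines, so the bearing of the data is indirect: the steps of a number 13.4 percentage points lower from compound 1 to compound 2 (beyond the scatter) and a number 133.5 percentage points lower from compound 2 to compound 3 (beyond the scatter) show that changes on this ring move this assay anywhere from modest to large. The strong response of compound 3 cannot be assumed to carry over, so compound 4 is expected to lie higher, with a number 76.1 percentage points higher from compound 3 to compound 4 (beyond the scatter). The estimate for compound 4 is -10%, within -90% to 60%.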

Compound 4, a percentage reported as activity, at one concentration (the size of the read-out at that concentration, not a potency): -35%
Estimate against measurement, compound 4: 25 percentage points above; the measured number falls inside the stated range.
By their numbers in this assay, from the lowest: compound 3; then compound 4; then compound 2; then compound 1.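

In this assay, the strong response is not unique to 3-(trifluoromethyl)phenyl on this urea nitrogen: 3,4-dichlorophenyl also gives a much lower number than phenyl, with a number 95.8 percentage points lower from compound 1 to compound 4 (beyond the scatter), and than 4-(trifluoromethyl)phenyl, with a number 82.4 percentage points lower from compound 2 to compound 4 (beyond the scatter). The two strongly responding rings are still not interchangeable, as a number 51.1 percentage points higher from compound 3 to compound 4 (beyond the scatter) shows. No evidence on the cause of these differences is available.

Open, going by these compounds, is whether a single chlorine would suffice. Also open, on these data alone, is how a methoxy, a nitrile or an amine on this ring would read.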